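This account rests on a few compounds, and the source may have more. Where it says the series, first, only, none or still open, it means among the compounds named here.

Measured compounds:
- compound 1 `CC(C)c1n[nH]c2c(NCc3ccc(-c4ccccn4)cc3)nc(SCCNC(=N)N)nc12`: 390 nM in a functional assay on HT cells (Homo sapiens) for antiproliferative activity, read by fluorescence, with a stated time of 72 h; a higher number here means a weaker inhibitor of growth, a lower number a stronger inhibitor of growth
- compound 2 `CC(C)c1n[nH]c2c(NCc3ccc(-c4ccccn4)cc3)nc(SCC(O)CN3CCNCC3)nc12`: 332 nM
- compound 3 `COCSc1nc(NCc2ccc(-c3ccccn3)cc2)c2[nH]nc(C(C)C)c2n1`: 340 nM

Compound 3 sits second highest of the three numbers in this assay, with compound 2 nearest and compound 1 furthest, both within the scatter. Every change so far has been at the saturated chain carbon bound to the sulfur, and none moved the number beyond the scatter: a 1.2-fold lower number from compound 1 to compound 2 (0.07 log units; within the scatter), a 1.1-fold lower number from compound 1 to compound 3 (0.06 log units; within the scatter), a 1.0-fold higher number from compound 2 to compound 3 (0.01 log units; within the scatter).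

Compound 4 `CC(=O)NCCSc1nc(NCc2ccc(-c3ccccn3)cc2)c2[nH]nc(C(C)C)c2n1` continues at the same place: acetamidomethyl in place of methoxy on a saturated chain carbon bound to a sulfur. Since all three prior steps at this position stayed within the scatter, no step beyond the scatter is expected here either; a 1.0-fold higher number from compound 3 to compound 4 (0.01 log units; within the scatter) is the estimated change. Compound 4 is expected to give about 350 nM, with a range from 170 nM to 720 nM.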

Compound 4, concentration for 50% growth inhibition: 71 nM
For compound 4 the middle estimate is 4.9-fold (0.69 log units) above the measured one; the whole stated range lies above it.
By their numbers in this assay, from the lowest: compound 4; then compounds 2, 3 and 1 (each within the scatter of the next).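

Among these compounds, the saturated chain carbon bound to a sulfur is not indifferent to substitution in this assay: the 2-acetamidoethyl chain gives a 4.8-fold lower number from compound 3 to compound 4 (0.68 log units; beyond the scatter) and a 4.7-fold lower number from compound 2 to compound 4 (0.67 log units; beyond the scatter) and also a 5.5-fold lower number from compound 1 to compound 4 (0.74 log units; beyond the scatter) as the first steps beyond the scatter. The last of these is a change on an amine nitrogen, with the chain leading to that nitrogen kept. No measurement shown bears on the reason for these steps.

As far as these compounds go, whether the amide hydrogen or the carbonyl matters remains open. So does whether a longer chain or a carboxylic acid in place of the acetamide would keep the lower number.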